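Notes on an aryl exchange within one series

The source may report more compounds than this note shows. Statements on the series, on what has been measured and on what is new or still open speak of the compounds shown alone.

Of the compounds shown here, three have so far been measured in a functional assay on U-87MG ATCC cells for antiproliferative activity against U-87 MG (Homo sapiens), read by MTT assay, with a stated time of 48 h, tested at 50 uM; a lower number here means a stronger effect, a higher number a weaker effect of the compound at the concentration tested. Compound 1 `COc1ccc(-c2nc(C)c(C(=O)CSc3nc(N)c(C#N)c(-c4ccc(Cl)cc4)n3)s2)cc1` gives 23.1%. Compound 2 `COc1ccc(-c2nc(C)c(C(=O)CSc3nc(N)c(C#N)c(-c4ccccc4)n3)s2)cc1` gives 16.5%; the step of a number 6.6 percentage points lower from compound 1 to compound 2 (within the scatter) is within the scatter. Compound 3 `COc1ccc(-c2nc(C)c(C(=O)CSc3nc(-c4ccc(Cl)cc4)c(C#N)c(=O)[nH]3)s2)cc1` gives 48%, the highest of the three numbers and therefore the weakest effect at the concentration tested, its gaps to compound 1 and to compound 2 both beyond the scatter.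

Compound 4 `COc1ccc(-c2nc(C)c(C(=O)CSc3nc(-c4ccc(OC)c(OC)c4)c(C#N)c(=O)[nH]3)s2)cc1` differs from compound 3 in one place: 3,4-dimethoxyphenyl in place of 4-chlorophenyl on an aromatic carbon. Among the compounds with values here, the only measured step that bears on this is also an exchange on an aromatic carbon, a number 6.6 percentage points lower from compound 1 to compound 2 (within the scatter), which stayed within the scatter. No step beyond the scatter is therefore expected in this assay. For compound 4 the estimate is 45%, between 30% and 62%. This corresponds to an expected step of a number 3 percentage points lower from compound 3 to compound 4 (within the scatter).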

Compound 4, a percentage reported as activity, at one concentration (the size of the read-out at that concentration, not a potency): 22.2%
Compound 4: middle estimate off by 22.8 percentage points, on the high side; measured number outside the range, below it.
By their numbers in this assay, from the lowest: compounds 2, 4 and 1 (each within the scatter of the next); then compound 3.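

The aryl group on this aromatic carbon, ortho to a cyano group, is not a silent place in this assay: 3,4-dimethoxyphenyl in place of 4-chlorophenyl gives a number 25.8 percentage points lower from compound 3 to compound 4 (beyond the scatter). Within the data shown here, the earlier step, a number 6.6 percentage points lower from compound 1 to compound 2 (within the scatter), only removed chloro from such an aryl group, so this is the first exchange here seen to move the read-out. Among these compounds, nothing measured so far explains the step.

Open, from the compounds shown here alone, is whether a single methoxy on this aryl group, or an amine or a carboxylic acid in its place, would give a similar read-out. Also open, going by these compounds, is whether the same exchange would hold on the core of compound 1.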